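This account rests on a few compounds, and the source may have more. Where it says the series, first, only, none or still open, it means among the compounds named here.

Compound 3 `Cc1ccccc1CN(C)CC1(O)CCN(CCCc2c[nH]c3ccc(-n4cnnc4)cc23)CC1` sits second highest of the three numbers in a functional assay on CHO cells for agonist activity at 5-hydroxytryptamine receptor 1D (Homo sapiens), read by GTPgammaS binding (a higher number here means that more compound is needed for the effect, a lower number that less compound is needed), giving 3.7 nM. Compound 1 `CN(CC1CC1)CC1(O)CCN(CCCc2c[nH]c3ccc(-n4cnnc4)cc23)CC1` gives 1.1 nM, and compound 2 `CC(=O)Nc1ccc(CNCC2(O)CCN(CCCc3c[nH]c4ccc(-n5cnnc5)cc34)CC2)cc1` gives 14 nM. Compound 4 `OC1(CNCc2ccccc2)CCN(CCCc2c[nH]c3ccc(-n4cnnc4)cc23)CC1` has not yet been measured; it differs from compound 3 as follows: benzylamino in place of methyl(2-methylbenzyl)amino on a saturated chain carbon bound to a saturated ring carbon. Among the measured compounds shown here, two measured steps bear on this change. The step of a 3.4-fold higher number from compound 1 to compound 3 (0.53 log units; beyond the scatter) shows that the 2-methylphenyl group costs a modest amount, while the step of a 3.8-fold lower number from compound 2 to compound 3 (0.58 log units; beyond the scatter) shows that the secondary benzylamine with an acetamido group is weaker still. Compound 4, a secondary benzylamine without the acetamido group, is therefore expected to fall between compound 3 and compound 2, an expected step of a 1.9-fold higher number from compound 3 to compound 4 (0.28 log units; within the scatter). Compound 4 is estimated at 7 nM, within a range of 2.5 nM to 20 nM.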

Compound 4, concentration for half-maximal effect: 2.2 nM
For compound 4 the middle estimate is 3.2-fold (0.50 log units) above the measured one, outside the stated range (below it).
By their numbers in this assay, from the lowest: compounds 1, 4 and 3 (each within the scatter of the next, the first and the last beyond it); then compound 2.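

In this assay, benzylamino on this saturated chain carbon gives a 1.7-fold lower number from compound 3 to compound 4 (0.23 log units; within the scatter) and also a 2.0-fold higher number from compound 1 to compound 4 (0.30 log units; within the scatter), so this secondary benzylamine reads alike with both tertiary amines. The higher number of compound 2 therefore goes with the acetamido group and not with the secondary amine, since hydrogen in its place on the aromatic carbon gives a 6.4-fold lower number from compound 2 to compound 4 (0.80 log units; beyond the scatter). Still open, going by these compounds, is whether methoxy or an amine on that aromatic carbon would read like hydrogen or like acetamido, and whether phenethylamino would match benzylamino. Nothing measured here gives a reason for these steps.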